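The compounds below may be only part of what the source reports. "The series", "measured", "known", "first", "only" and "open" are said of these compounds alone.

Measured so far:
compound 1 `COc1cc(C)cc(-c2c(-c3ccnc(-c4ccc(C(C)=O)cc4)c3)cnn2CC#N)c1` — 83%
compound 2 `COc1cc(C)cc(-c2nn(CC#N)cc2-c2ccc(-c3cccc(C(C)=O)c3)nc2)c1` — 85%

In a functional assay on PC-3 cells (Homo sapiens) for cytotoxicity, read by sulforhodamine B assay, with a stated time of 48 h, tested at 100 nM (on this read-out higher numbers stand for a weaker effect at the one concentration tested and lower numbers for a stronger effect), compound 1 gives 83% and compound 2 gives 85%; the two numbers lie within the usual scatter of each other, so neither stands apart. Compound 3 `COc1cc(C)cc(-c2c(-c3ccnc(-c4ccc(N(C)C)cc4)c3)cnn2CC#N)c1` is not yet measured. It differs from compound 1 in one place: dimethylamino in place of acetyl on an aromatic carbon. Among the compounds with values here, no step between measured compounds shows how large such a change reads here; the step of a number 1 percentage points lower from compound 1 to compound 3 (within the scatter) is expected to stay within the scatter, with no clear direction. Compound 3 is therefore expected to give about 82%, with a range from 65% to 95%.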

Compound 3, a percentage reported as activity, at one concentration (the size of the read-out at that concentration, not a potency): 11%
Estimate against measurement, compound 3: 71 percentage points above; the whole stated range lies above it.
By their numbers in this assay, from the lowest: compound 3; then compounds 1 and 2 (each within the scatter of the next).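

In this assay, 4-(dimethylamino)phenyl in place of 4-acetylphenyl gives a step of a number 72 percentage points lower from compound 1 to compound 3 (beyond the scatter), so the substituent at this place, para to a large group, strongly affects the read-out. The two groups have equal counts of heavy atoms and hydrogen-bond acceptors, so those counts do not separate them. Nothing available bears on what lies behind the step. Going by these compounds, whether a primary amine, diethylamino or a methoxy group here keeps the stronger effect remains open. Also open, on these data alone, is whether dimethylamino acts the same way on the scaffold of compound 2.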